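The source may report more compounds than this note shows. Statements on the series, on what has been measured and on what is new or still open speak of the compounds shown alone.

Among the measured compounds shown here, in a functional assay on HT-29 cells (Homo sapiens) for inhibition, read by MTT assay (a higher number here means a weaker inhibitor, a lower number a stronger inhibitor), three compounds have numbers so far. Compound 1 (`COc1ccc2c(c1)CC[C@H](O)/C2=C/c1cc(OC)c(OC)c(OC)c1`) gives 1 nM, compound 2 (`COc1ccc(/C=C2\c3cc(OC)c(OC)c(OC)c3CC[C@@H]2O)cc1C#N`) gives 5 nM, and compound 3 (`COc1ccc(/C=C2\c3cc(OC)c(OC)c(OC)c3CC[C@@H]2O)cc1N`) gives 160 nM. Compound 3 therefore has the highest number of the three and is the weakest inhibitor among them, with both gaps beyond the scatter.

Compound 4 (`COc1ccc(/C=C2\c3cc(OC)c(OC)c(OC)c3CC[C@@H]2O)cc1C(N)=O`) keeps the core of compound 3 but has carbamoyl in place of amino on an aromatic carbon, ortho to a methoxy group: carbamoyl in place of amino on an aromatic carbon. For the measured compounds named here, one measured step bears on this same carbon, a 32-fold higher number from compound 2 to compound 3 (1.51 log units; beyond the scatter), where amino replaces cyano. That step is large, so the group at this carbon clearly matters in this assay. However, no measured compound carries carbamoyl, and the direction of the new step cannot be read from the data. A step within the scatter is the most reasonable expectation, with a wide margin on either side. The estimated step is a 1.3-fold higher number from compound 3 to compound 4 (0.10 log units; within the scatter). For compound 4 the expected value is 200 nM, with an estimated range from 30 nM to 1000 nM.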

Compound 4, half-maximal inhibitory concentration: 550 nM
The estimate for compound 4 lay 2.8-fold (0.44 log units) below the measured number; the measured number falls inside the stated range.
By their numbers in this assay, from the lowest: compound 1; then compound 2; then compound 3; then compound 4.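

In this assay, the move from amino to carbamoyl gives a 3.4-fold higher number from compound 3 to compound 4 (0.54 log units; beyond the scatter), so the number at this aromatic carbon keeps rising even after the loss of the nitrile, and against the nitrile itself the change is a 110-fold higher number from compound 2 to compound 4 (2.04 log units; beyond the scatter). Of the three groups compared here, nitrile gives the lowest number, then amino, then carbamoyl; amino and carbamoyl have the same printed count of hydrogen-bond donors and acceptors, so those counts alone do not separate them. Nothing available here accounts for this order.

The compounds shown leave open how a carboxylic acid, a methyl ester or a hydroxyl group would rank against these three at this carbon. They also leave open whether the same order would hold on the core of compound 1.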